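Methoxy on the benzyl ring of a diaminopurine imine

The source may report more compounds than this note shows. Statements on the series, on what has been measured and on what is new or still open speak of the compounds shown alone.

Within the data shown here, compound 2 `CCCCCCCC/N=c1\nc(N)c2ncn(Cc3ccccc3)c2c(N)n1` gives 5930 nM in a functional assay on PC-3 cells (Homo sapiens) for antiproliferative activity, read by WST assay, with a stated time of 72 h; a lower number here means a stronger inhibitor, a higher number a weaker inhibitor; the only other number, from compound 1 `CCCCCCCCCCCCCCCCCC/N=c1\nc(N)c2ncn(Cc3ccccc3)c2c(N)n1` at 5450 nM, lies so close that a 1.1-fold higher number from compound 1 to compound 2 (0.04 log units; within the scatter), so the two stand together. Compound 3 `CCCCCCCC/N=c1\nc(N)c2ncn(Cc3ccc(OC)cc3)c2c(N)n1` carries methoxy in place of hydrogen on an aromatic carbon. Among the measured compounds shown here, no measured step touches the benzyl ring; the one step known, the shortening of the chain, stayed within the scatter. The step of a 1.0-fold higher number from compound 2 to compound 3 (0.01 log units; within the scatter) is therefore expected to stay within the scatter as well. Compound 3 is estimated at 6000 nM, with a range of 3000 nM to 12000 nM.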

Compound 3, half-maximal inhibitory concentration: 5900 nM
The estimate for compound 3 lay 1.0-fold (0.01 log units) above the measured number; the range from low to high includes it.
By their numbers in this assay, from the lowest: compounds 1, 3 and 2 (each within the scatter of the next).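

The benzyl ring now has a measured step: 4-methoxybenzyl in place of benzyl, with methoxy on an aromatic carbon para to a large group, gives a 1.0-fold lower number from compound 2 to compound 3 (0.00 log units; within the scatter) in this assay. This single change at this ring position therefore stays within the scatter, as does the chain step, a 1.1-fold higher number from compound 1 to compound 2 (0.04 log units; within the scatter). No evidence on hand speaks to the reason for this result.

Still open, going by these compounds, is whether an amine or a carboxylic acid at the same ring carbon would step beyond the scatter. Also open, on these data alone, is whether methoxy there reads the same on the longer chain of compound 1.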